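Swapping chloro for methyl on a short-lived compound

A few compounds are considered here, and "the series" means these few. Any claim that something is new, unique, unknown or untested is made for them only; others in the source may bear on it.

Among the measured compounds shown here, in an ADME assay on microsomes from liver (Homo sapiens) for metabolic stability, using NADPH, with a stated time of 40 min, tested at 2 uM (on this read-out lower numbers stand for a shorter-lived compound and higher numbers for a longer-lived compound), compound 1 `Fc1ccc2c(-c3ccc4ccccc4n3)c[nH]c2c1Cl` gives 0.183 h, at the short end of the numbers known so far and within the scatter of compound 2 `Clc1cccc2c(-c3ccc4ccccc4n3)c[nH]c12` at 0.283 h. Compound 3 `Cc1cccc2c(-c3ccc4c(C(F)(F)F)cccc4n3)c[nH]c12` reads 1.25 h. Compound 4 `Cc1c(F)ccc2c(-c3ccc4ccccc4n3)c[nH]c12` comes from compound 1 through one change: methyl in place of chloro on an aromatic carbon. Compound 3 also carries a methyl, but it differs elsewhere too, with a trifluoromethyl group, so it cannot isolate this swap. For the measured compounds named here, the only measured step, a 1.5-fold higher number from compound 1 to compound 2 (0.19 log units; within the scatter), concerns fluoro rather than chloro and stayed small. With so little evidence, no shift beyond the scatter is expected in this assay, and the estimated step is a 1.3-fold higher number from compound 1 to compound 4 (0.10 log units; within the scatter). Compound 4 is estimated at 0.23 h, with an expected range of 0.1 h to 0.55 h.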

Compound 4, half-life: 0.433 h
Compound 4: middle estimate off by 1.9-fold (0.27 log units), on the low side; low and high end bracket the measured number.
By their numbers in this assay, from the lowest: compounds 1, 2 and 4 (each within the scatter of the next, the first and the last beyond it); then compound 3.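

Placing methyl instead of chloro on this aromatic carbon, ortho to a fluoro group, gives a 2.4-fold higher number from compound 1 to compound 4 (0.37 log units; beyond the scatter) in this assay, so the group at this position can move the half-life modestly. The earlier measured step, at the neighbouring fluoro site of the core, had stayed within the scatter. Nothing measured here explains the shift. Still open, going by these compounds, is how an ethyl group, a longer chain or an amine on this carbon would read. Also open, on these data alone, is whether the swap behaves alike on the trifluoromethyl-bearing core of compound 3.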